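A few compounds are considered here, and "the series" means these few. Any claim that something is new, unique, unknown or untested is made for them only; others in the source may bear on it.

In an ADME assay on cells (Peritoneal macrophage, Mus musculus, strain Balb/c) for cytotoxicity, read by resazurin assay, with a stated time of 72 h (a higher number here means that more compound is tolerated, a lower number that less compound is tolerated), compound 1 `CC1(Cc2ccc([N+](=O)[O-])cc2)CC(S(=O)(=O)c2ccc(F)cc2)=C(c2ccc(/C(N)=N/O)cc2)O1` gives 97400 nM and compound 2 `Cc1cccc(CC2(C)CC(S(=O)(=O)c3ccc(F)cc3)=C(c3ccc(/C(N)=N/O)cc3)O2)c1` gives 112000 nM. Going by the values given here, these are the only two numbers so far, and they lie within the scatter of each other, so compound 2 stands level with compound 1.

The next structure is compound 3 `Cc1ccccc1CC1(C)CC(S(=O)(=O)c2ccc(F)cc2)=C(c2ccc(/C(N)=N/O)cc2)O1`. Its difference from compound 2 is 2-methylphenyl in place of 3-methylphenyl on a saturated chain carbon bound to a saturated ring carbon. In short, 2-methylphenyl stands in place of 3-methylphenyl on a saturated chain carbon bound to a saturated ring carbon.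

Among the compounds with values here, one measured step bears on this change, since it falls at the same place: a 1.1-fold higher number from compound 1 to compound 2 (0.06 log units; within the scatter). That step replaced 4-nitrophenyl with 3-methylphenyl and stayed within the scatter. Within the data shown here, the data hold no measured compound with 2-methylphenyl, so this single step is the only guide. On that basis, no step beyond the scatter is expected in this assay, and no direction can be assigned.

The estimated step is a 1.1-fold lower number from compound 2 to compound 3 (0.03 log units; within the scatter), which is expected to stay within the scatter. For compound 3 the estimated value is 105000 nM, with an expected range of 60000 nM to 180000 nM.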

Compound 3, half-maximal cytotoxic concentration: 77600 nM
Compound 3: middle estimate off by 1.4-fold (0.13 log units), on the high side, and the stated range covers the measured number.
By their numbers in this assay, from the lowest: compounds 3, 1 and 2 (each within the scatter of the next).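

In this assay, the swap of 3-methylphenyl for 2-methylphenyl on a saturated chain carbon bound to a saturated ring carbon gives a 1.4-fold lower number from compound 2 to compound 3 (0.16 log units; within the scatter), so these two methylphenyl groups stand level, and the same atoms joined differently open no gap here. Going by these compounds alone, the comparison with the nitro-bearing group gives a 1.3-fold lower number from compound 1 to compound 3 (0.10 log units; within the scatter), which adds a second swap at this place that stays within the scatter; with the earlier step, 4-nitrophenyl, 3-methylphenyl and 2-methylphenyl now form a set of three compounds with no pair separated beyond the scatter, whereas before only one pair could be compared. No supporting data bear on this result, so it stands as a plain observation on compounds 1, 2 and 3.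

All three groups shown at this place are substituted phenyl rings, so it remains open whether any group here can move the number beyond the scatter. A 4-methylphenyl group would complete the methyl series, while a group bearing an amine or a carboxylic acid, or a longer chain, would test this place with quite different atoms.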